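Replacing 3,5-dimethoxyphenyl with 3,5-difluorophenyl in compound 2

The source may hold more compounds than are shown below. What is called first, only, known or untested is meant among the compounds shown, and "the series" means these compounds.

Measured in a functional assay on HL-60 cells (Homo sapiens) for inhibition, read by MTT assay, with a stated time of 72 h; a higher number here means a weaker inhibitor, a lower number a stronger inhibitor:
Compound 1 `Cc1nc(-c2ccccc2F)c(C(=O)N2CCN(c3cc(Cl)cc(Cl)c3)CC2)o1`: 60.2 nM
Compound 2 `COc1cc(OC)cc(N2CCN(C(=O)c3oc(C)nc3-c3ccccc3F)CC2)c1`: 10.3 nM

Compound 2 has the lower of the two numbers. Compound 3 `Cc1nc(-c2ccccc2F)c(C(=O)N2CCN(c3cc(F)cc(F)c3)CC2)o1` carries 3,5-difluorophenyl in place of 3,5-dimethoxyphenyl on an amine nitrogen in a ring. Within the data shown here, only one measured step bears on this place: a 5.8-fold lower number from compound 1 to compound 2 (0.77 log units; beyond the scatter), with 3,5-dimethoxyphenyl in place of 3,5-dichlorophenyl. Compound 3 gives up that same 3,5-dimethoxyphenyl, so a move to a higher number, of similar or smaller size, is expected. The expected step is a 3.4-fold higher number from compound 2 to compound 3 (0.53 log units; beyond the scatter). In this assay, the estimated value for compound 3 is 35 nM, with an expected range from 12 nM to 100 nM.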

Compound 3, half-maximal inhibitory concentration: 186 nM
Compound 3: the middle estimate sits 5.3-fold (0.73 log units) below what was measured, outside the stated range (above it).
By their numbers in this assay, from the lowest: compound 2; then compound 1; then compound 3.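

In this assay the group on the amine nitrogen in the ring proves more influential than the first pair alone could show: 3,5-difluorophenyl brings an 18-fold higher number from compound 2 to compound 3 (1.26 log units; beyond the scatter). It also brings a 3.1-fold higher number from compound 1 to compound 3 (0.49 log units; beyond the scatter), so the two halogen-bearing groups do not behave alike at this place, and all three groups separate beyond the scatter. Nothing measured here accounts for this order.

From the compounds shown here alone, how an unsubstituted phenyl or a 3,5-diethoxyphenyl would fall at this place remains open. So does whether the same order holds when the 2-fluorophenyl group of the shared core is replaced by another group.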